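Swapping an Amide for an Ester on the Linker Chain

The compounds below may be only part of what the source reports. "The series", "measured", "known", "first", "only" and "open" are said of these compounds alone.

Measured so far, in a physicochemical assay for lipophilicity, read by LC-MS, using the shake flask method, in phosphate buffer, with a stated time of 50 min, at pH 7.4; on this read-out lower numbers stand for lower lipophilicity and higher numbers for higher lipophilicity:
Compound 1, `Cc1ncsc1-c1ccc(CNC(=O)[C@@H]2C[C@@H](O)CN2C(=O)[C@@H](NC(=O)CCCCCOC(=O)CC(c2ccccc2)c2ccccc2)C(C)(C)C)cc1`, gives 1.9.
Compound 2, `CCCCOc1ccc(-c2ccc(C(=O)NCCCCCC(=O)N[C@H](C(=O)N3C[C@H](O)C[C@H]3C(=O)NCc3ccc(-c4scnc4C)cc3)C(C)(C)C)cc2)cc1`, gives 1.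
Compound 3, `CCCC(=O)NCCCCCC(=O)N[C@H](C(=O)N1C[C@H](O)C[C@H]1C(=O)NCc1ccc(-c2scnc2C)cc1)C(C)(C)C`, gives 2.2.

Compound 3 shows the highest of the three numbers. Compound 1 sits close to it, within the usual scatter, so the two cannot be ranked against each other; compound 2 lies further down, beyond the scatter.

Compound 4, `CCCC(=O)OCCCCCC(=O)N[C@H](C(=O)N1C[C@H](O)C[C@H]1C(=O)NCc1ccc(-c2scnc2C)cc1)C(C)(C)C`, differs from compound 3 in one place: (propylcarbonyl)oxy in place of (propylcarbonyl)amino on a saturated chain carbon, five bonds along the chain from a carbonyl carbon. Going by the values given here, no pair of measured compounds shows this same change, so its size is not known from these data. The expectation is a moderate rise in this assay, a step of a number 0.70 log units higher from compound 3 to compound 4 (beyond the scatter), beyond the scatter. Compound 4 is thus estimated at 2.9, with a range from 2.3 to 3.5.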

Compound 4, distribution coefficient: 0.5
Estimate against measurement, compound 4: 2.40 log units above; the measured number lies below the stated range.
By their numbers in this assay, from the lowest: compound 4; then compound 2; then compounds 1 and 3 (each within the scatter of the next).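

Putting (propylcarbonyl)oxy in place of (propylcarbonyl)amino on this saturated chain carbon, five bonds along the chain from a carbonyl carbon, gives in this assay a number 1.70 log units lower from compound 3 to compound 4 (beyond the scatter). Both groups hold 6 heavy atoms and carry no net charge, so exchanging a single atom at this place is enough for a large step. Nothing at hand accounts for this step.

Still open, from the compounds shown here alone, is how this position responds to other groups: a longer chain on the same ester, an amine or a carboxylic acid on this chain carbon.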